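Shrinking the Ring on the Thiocarbonyl Carbon

The compounds below may be only part of what the source reports. "The series", "measured", "known", "first", "only" and "open" are said of these compounds alone.

Going by the values given here, compound 2 `Cc1ccnc(/C(N)=N/NC(=S)N2CCCCC2)c1` gives 39.7% in a functional assay on A-431 cells (Homo sapiens) for cytotoxicity, read by MTT assay, with a stated time of 72 h, tested at 10 uM (a higher number here means more inhibition of growth at the concentration tested, a lower number less inhibition of growth), and stands as the lower of the two numbers measured so far. Compound 1 `Cc1ccnc(/C(N)=N/NC(=S)N2CCOCC2)c1` gives 62% in this assay. Among the compounds with values here, the only measured change at the thiocarbonyl carbon is a number 22.3 percentage points lower from compound 1 to compound 2 (beyond the scatter), where morpholin-4-yl gave way to piperidin-1-yl. Compound 3 `Cc1ccnc(/C(N)=N/NC(=S)N2CCCC2)c1` has not yet been measured; it differs from compound 2 by pyrrolidin-1-yl in place of piperidin-1-yl on a thiocarbonyl carbon. Within the data shown here, the one measured step bears on this only loosely, since it swapped one six-membered ring for another, whereas here the six-membered ring becomes a five-membered one with the same single hetero atom. The two numbers at hand give no indication of how a smaller ring would fare, so a change within the scatter, or at most a modest one, is expected. Compound 3 is therefore estimated to give 38%, between 20% and 58%. The expected step is a number 1.7 percentage points lower from compound 2 to compound 3 (within the scatter).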

Compound 3, percent growth inhibition at one concentration: 71.2%
Beside the measured number, compound 3's estimate is 33.2 percentage points below it, and the stated range ends below it.
By their numbers in this assay, from the lowest: compound 2; then compounds 1 and 3 (each within the scatter of the next).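

Replacing piperidin-1-yl with pyrrolidin-1-yl gave a number 31.5 percentage points higher from compound 2 to compound 3 (beyond the scatter), so in this assay the ring on the thiocarbonyl carbon can change the result strongly even when the ring keeps the same single hetero atom. Exchanging morpholin-4-yl for pyrrolidin-1-yl gave a number 9.2 percentage points higher from compound 1 to compound 3 (within the scatter), which leaves piperidin-1-yl as the one ring of the three set apart from the other two by steps beyond the scatter. Nothing available explains why this position responds in this way.

The compounds shown leave open how azetidin-1-yl, azepan-1-yl or an open-chain dimethylamino group would behave on the thiocarbonyl carbon. They also leave open whether the same differences among these rings would persist if the methyl group on the shared core were replaced by a chlorine atom.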